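A few compounds are considered here, and "the series" means these few. Any claim that something is new, unique, unknown or untested is made for them only; others in the source may bear on it.

Of the compounds shown here, three have been tested in an ADME assay on NIH3T3 cells (Mus musculus) for cytotoxicity, read by neutral red uptake, with a stated time of 24 h; a higher number here means that more compound is tolerated, a lower number that less compound is tolerated. Compound 1 `Clc1ccc(C(Nc2ccnc3cc(Cl)ccc23)c2ccc(Cn3ccnc3)cc2)cc1` gives 35 uM, compound 2 `Fc1cc(C(Nc2ccnc3cc(Cl)ccc23)c2ccc(Cl)cc2)ccc1CN1CCCC1` gives 25 uM, and compound 3 `Clc1ccc(C(Nc2ccnc3cc(Cl)ccc23)c2ccc(CN3CCNCC3)cc2)cc1` gives 1.8 uM. Compound 2 stands second highest of the three; its value sits within the scatter of that of compound 1, while compound 3 lies well below it. Among the measured compounds shown here, the one measured step, a 19-fold lower number from compound 1 to compound 3 (1.29 log units; beyond the scatter), concerns a swap of the amine group and therefore says nothing about a halogen change. Compound 4 `Clc1ccc(C(Nc2ccnc3cc(Cl)ccc23)c2ccc(CN3CCCC3)c(Cl)c2)cc1` differs from compound 2 by chloro in place of fluoro on an aromatic carbon. For the measured compounds named here, with no step of this kind measured, no change beyond the scatter is expected in this assay, so compound 4 is expected to give 25 uM, between 12 uM and 50 uM, a step of no change at the digits printed from compound 2 to compound 4 (within the scatter).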

Compound 4, half-maximal toxic concentration: 16 uM
Estimate against measurement, compound 4: 1.6-fold (0.19 log units) above; the range from low to high includes it.
By their numbers in this assay, from the lowest: compound 3; then compounds 4, 2 and 1 (each within the scatter of the next, the first and the last beyond it).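

In this assay, among the compounds shown here, chloro in place of fluoro on an aromatic carbon, ortho to a (pyrrolidin-1-yl)methyl group, gives a 1.6-fold lower number from compound 2 to compound 4 (0.19 log units; within the scatter) and so is the first halogen change that can be read. At this position, the two halogens cannot be told apart in this assay. No measurement here offers an explanation for this result. Still open, going by these compounds, is whether a methyl or methoxy group at this position would give a step beyond the scatter, and whether the same halogen change would behave alike with a piperazin-1-yl group in place of the pyrrolidin-1-yl ring.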